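The compounds below may be only part of what the source reports. "The series", "measured", "known", "first", "only" and "open" are said of these compounds alone.

Working notes on the series. For the measured compounds named here, in a functional assay (muscle tissue) with Cavia porcellus as the target (a lower number here means that less compound is needed, a higher number that more compound is needed for the effect), compound 1 `COC(=O)C1=C(C)N=C(C)/C(=C(\O)OC)C1c1ccccc1N` gives 39800 nM, the highest of the three numbers measured so far. Compound 2 `COC(=O)C1=C(C)N=C(C)/C(=C(\O)OC)C1c1ccccc1I` gives 46.8 nM and compound 3 `COC(=O)C1=C(C)N=C(C)/C(=C(\O)OC)C1c1ccccc1F` gives 42.7 nM. Both measured steps away from compound 1 are large: an 850-fold lower number from compound 1 to compound 2 (2.93 log units; beyond the scatter) and a 930-fold lower number from compound 1 to compound 3 (2.97 log units; beyond the scatter). Between the two halogen compounds the step is a 1.1-fold lower number from compound 2 to compound 3 (0.04 log units; within the scatter), so those two numbers cannot be told apart.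

Compound 4 `COC(=O)C1=C(C)N=C(C)/C(=C(\O)OC)C1c1ccccc1Br` is not yet measured in this assay. It differs from compound 1 by bromo in place of amino on an aromatic carbon. The two steps that bear on this change are those from compound 1 to compound 2 and from compound 1 to compound 3, each exchanging the amino group on an aromatic carbon for a halogen, and each brought a large drop in the number. The bromo compound is expected to follow the same course, with a large step downward in this assay of a size close to an 850-fold lower number from compound 1 to compound 2 (2.93 log units; beyond the scatter) and a 930-fold lower number from compound 1 to compound 3 (2.97 log units; beyond the scatter). For compound 4 the expected value is 45 nM, with a range from 18 nM to 120 nM. The step this estimate implies is an 880-fold lower number from compound 1 to compound 4 (2.95 log units; beyond the scatter), expected to lie well beyond the scatter.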

Compound 4, half-maximal effective concentration: 7.59 nM
Compound 4: the middle estimate sits 5.9-fold (0.77 log units) above what was measured; the measured number lies below the stated range.
By their numbers in this assay, from the lowest: compound 4; then compounds 3 and 2 (each within the scatter of the next); then compound 1.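

In this assay, the position on an aromatic carbon ortho to a large group now separates the halogens: with a 5.6-fold lower number from compound 3 to compound 4 (0.75 log units; beyond the scatter) and a 6.2-fold lower number from compound 2 to compound 4 (0.79 log units; beyond the scatter), bromo stands apart from both fluoro and iodo, which alone could not be told apart. Replacing amino with a halogen therefore does not produce one shared drop, and bromo in place of amino gives the largest step yet from the amino compound, a 5200-fold lower number from compound 1 to compound 4 (3.72 log units; beyond the scatter). Read in the order fluoro, bromo, iodo, the numbers do not run in one direction, since compound 4 sits alone at the low end while compound 3 and compound 2 remain within the scatter of each other.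

Nothing available here accounts for the separate standing of the bromo compound. The compounds shown leave open whether chloro, methyl or trifluoromethyl at this place would fall with bromo or with fluoro and iodo, and whether bromo would keep its standing on another carbon of the aromatic ring.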